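The source may hold more compounds than are shown below. What is called first, only, known or untested is meant among the compounds shown, and "the series" means these compounds.

Three compounds in the series carry numbers in an ADME assay on NIH3T3 cells (Mus musculus) for cytotoxicity, read by MTT assay, with a stated time of 72 h; a higher number here means a weaker inhibitor, a lower number a stronger inhibitor. Compound 1 `COc1ccc(/C=C/C(=O)CC(C)=O)cc1OC` gives 18100 nM, the lowest of the three. Compound 2 `CC(=O)/C=C(O)/C=C/c1ccc(O)c(O)c1` gives 51200 nM, a higher number beyond the scatter, and compound 3 `Cc1cc(/C=C/c2ccc(O)c(O)c2)[nH]n1` gives 88400 nM, the furthest from compound 1. No pair among these differs in one place only, so no single step can be read off. Compound 4 `COc1ccc(/C=C/c2cc(C)no2)cc1OC` is not yet measured in this assay. It differs from compound 1 as follows: 3-methyl-1,2-oxazol-5-yl in place of (2-oxopropyl)carbonyl on a double-bonded chain carbon bound to a double-bonded chain carbon. Since compound 2 and compound 3 both sit at higher numbers than compound 1, and the change removes the chain that compound 1 alone carries, a modest rise is expected, so the step of a 1.9-fold higher number from compound 1 to compound 4 (0.29 log units; within the scatter) should reach beyond the scatter. Compound 4 is expected to give 35000 nM, within 14000 nM to 90000 nM.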

Compound 4, half-maximal inhibitory concentration: 93200 nM
Estimate against measurement, compound 4: 2.7-fold (0.43 log units) below; measured number outside the range, above it.
By their numbers in this assay, from the lowest: compound 1; then compounds 2, 3 and 4 (each within the scatter of the next).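

In this assay, among these compounds, 3-methyl-1,2-oxazol-5-yl in place of (2-oxopropyl)carbonyl gives a 5.1-fold higher number from compound 1 to compound 4 (0.71 log units; beyond the scatter) at this position, the only single-place step that can be read. Both groups have the same heavy-atom, donor and acceptor counts, yet the step lies beyond the scatter, showing that these counts alone do not fix the number here. No measured property of either group is available to explain the step. Going by these compounds, whether a carboxylic acid or a simple amide on this carbon would give a number nearer compound 1 or compound 4 remains open. Also open, on these data alone, is whether the step keeps its size with other groups on the core of compound 1.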